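Swapping butoxy for pentyl on a sulfonamide series

The source may report more compounds than this note shows. Statements on the series, on what has been measured and on what is new or still open speak of the compounds shown alone.

compound 1 `CCCCCCCc1ccc(NS(=O)(=O)c2ccc(N3CCNC3=O)cc2)cc1`: > 1000 nM
compound 2 `CCCCOc1ccc(NS(=O)(=O)c2ccc(N3CCNC3=O)cc2)cc1`: 580 nM

Going by the values given here, in a functional assay on M21 cells (Homo sapiens) for antiproliferative activity, read by sulforhodamine B assay, with a stated time of 48 h (a lower number here means a stronger inhibitor, a higher number a weaker inhibitor), compound 2 gives 580 nM, the only exact number so far. Compound 1 gives > 1000 nM, which is a limit of the assay and not a number.

Compound 3 `CCCCCc1ccc(NS(=O)(=O)c2ccc(N3CCNC3=O)cc2)cc1` differs from compound 2 by one change: pentyl in place of butoxy on an aromatic carbon. Among the compounds with values here, only one measured step bears on it: an at least 1.7-fold lower number from compound 1 to compound 2 (0.23 log units; that floor lies within the scatter), with butoxy in place of heptyl on an aromatic carbon. From the compounds shown here alone, its true size is unknown, since it starts from a limit. Compound 3 carries an all-carbon chain, as compound 1 does, so that step points to a modest move towards a higher number in this assay, probably not far beyond the scatter. The expected change is a 1.4-fold higher number from compound 2 to compound 3 (0.14 log units; within the scatter). For compound 3 the estimate is 800 nM, with an expected range from 350 nM to 1800 nM.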

Compound 3, half-maximal inhibitory concentration: 870 nM
Compound 3: middle estimate off by 1.1-fold (0.04 log units), on the low side; measured number inside the range.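

In this assay, the direct exchange at this position gives a 1.5-fold higher number from compound 2 to compound 3 (0.18 log units; within the scatter). Butoxy and pentyl have the same heavy-atom count, so this pair isolates the swap of one oxygen for one carbon, and at this position that swap produces no change beyond the scatter. Shortening the all-carbon chain gives an at least 1.1-fold lower number from compound 1 to compound 3 (0.06 log units; that floor lies within the scatter), but the value of compound 1 is a limit and not a number, and because of that the full size of this step remains unknown: the limit of > 1000 nM in this assay, at which 1 of the 3 values shown sits.

From the compounds shown here alone, it remains open whether the same exchange would also stay within the scatter on a shorter chain, such as ethoxy against propyl. The compounds shown also leave open how an amine or a carboxylic acid at this position would compare with butoxy and pentyl.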